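Hydroxy to ethyl on the chain of compound 3

The source may hold more compounds than are shown below. What is called first, only, known or untested is meant among the compounds shown, and "the series" means these compounds.

Compound 3 `Cc1nc(CO)nc2c1CCC(=O)N2Cc1ccc(-c2ccccc2-c2nn[nH]n2)cc1` gives -30% in a functional assay on the whole organism (artery) with Rattus norvegicus as the target, with a stated time of 60 min, at a dose of 3 mg/kg by the intraduodenal route (a lower number here means less inhibition, a higher number more inhibition at the dose given (going by the name of the read-out)), the highest of the three numbers measured. Compound 2 `Cc1nc(C(C)C)nc2c1CCC(=O)N2Cc1ccc(-c2ccccc2-c2nn[nH]n2)cc1` gives -40%, and the difference a number 10 percentage points higher from compound 2 to compound 3 (within the scatter) lies within the scatter, so no order between these two is claimed. Compound 1 `CCc1nc(C)c2c(n1)N(Cc1ccc(-c3ccccc3-c3nn[nH]n3)cc1)C(=O)CC2` gives -76%, and the step of a number 46 percentage points higher from compound 1 to compound 3 (beyond the scatter) is large.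

Compound 4 `CCCc1nc(C)c2c(n1)N(Cc1ccc(-c3ccccc3-c3nn[nH]n3)cc1)C(=O)CC2` differs from compound 3 in one place: ethyl in place of hydroxy on a saturated chain carbon bound to an aromatic carbon. The step that bears on it most directly is a number 46 percentage points higher from compound 1 to compound 3 (beyond the scatter), in which hydroxy entered in place of methyl at the same place and the number rose by a large amount. Compound 4 runs that change back and extends the chain further, so a large step downward is expected in this assay, about a number 35 percentage points lower from compound 3 to compound 4 (beyond the scatter). The step of a number 36 percentage points higher from compound 1 to compound 2 (beyond the scatter), methyl in place of hydrogen, is also large, so the wider range allows for compound 4 landing away from compound 1. Compound 4 is therefore estimated at -65%, with a range from -90% to -35%.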

Compound 4, a percentage reported as inhibition, in the whole organism at one dose (the size of the read-out at that dose, not a potency): -58%
Compound 4: the middle estimate sits 7 percentage points below what was measured, within the range that was stated.
By their numbers in this assay, from the lowest: compound 1; then compound 4; then compounds 2 and 3 (each within the scatter of the next).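

In this assay, methyl in place of hydrogen on a saturated chain carbon, two bonds along the chain from an aromatic carbon, moves the number by a modest step (a number 18 percentage points higher from compound 1 to compound 4 (beyond the scatter)), so the read-out at this position is not fixed from ethyl to propyl. Propyl also stands apart from its branched counterpart isopropyl (a number 18 percentage points lower from compound 2 to compound 4 (beyond the scatter)) and from hydroxymethyl (a number 28 percentage points lower from compound 3 to compound 4 (beyond the scatter)), so this position separates groups that compounds 1, 2 and 3 alone could not compare, and compound 4 falls within none of their scatter. No measurement on hand accounts for any of these steps. From the compounds shown here alone, whether a longer chain such as butyl continues the rise seen from ethyl to propyl remains open. An amine or a carboxylic acid at this place also remains untested among the compounds shown, so the hydroxymethyl result has no close polar-group neighbour to compare with.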